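Compound 3 to Compound 4: Neopentyl Enters at the Phenolic Oxygen

The source may report more compounds than this note shows. Statements on the series, on what has been measured and on what is new or still open speak of the compounds shown alone.

Compound 1 `COc1ccccc1N1CCN(CCCNc2ncccc2C(=O)C2CC2)CC1` gives 2 nM.
Compound 2 `COc1ccccc1N1CCN(CCCNc2ccccc2C(=O)c2ccccc2)CC1` gives 10 nM.
Compound 3 `CN(C)C(=O)c1cccnc1NCCCN1CCN(c2ccccc2O)CC1` gives 63.1 nM.

In a functional assay on aorta for antagonist activity at Alpha-1D adrenergic receptor (Rattus norvegicus) (a lower number here means tighter binding, a higher number weaker binding), compound 3 stands at the highest of the three numbers; compound 2 lies nearest to it, yet beyond the scatter, and compound 1 lies furthest, also beyond the scatter. Compound 4 `CN(C)C(=O)c1cccnc1NCCCN1CCN(c2ccccc2OCC(C)(C)C)CC1` differs from compound 3 in one place: neopentyl in place of hydrogen on an oxygen on an aromatic ring. Among the measured compounds shown here, no step between two measured compounds differing in a single place is available, and compounds 1 and 2 differ from compound 3 in more than one place, so the direction of this change can only be inferred loosely from the standing of compound 3 below them. A move of moderate size toward lower numbers, beyond the scatter, is expected, a 2.5-fold lower number from compound 3 to compound 4 (0.40 log units; beyond the scatter). Compound 4 is estimated at 25 nM, with a likely range from 6 nM to 100 nM.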

Compound 4, dissociation constant: 50.1 nM
Compound 4: middle estimate off by 2.0-fold (0.30 log units), on the low side, and the stated range covers the measured number.
By their numbers in this assay, from the lowest: compound 1; then compound 2; then compounds 4 and 3 (each within the scatter of the next).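

In this assay, neopentyl in place of hydrogen on an oxygen on an aromatic ring gives a 1.3-fold lower number from compound 3 to compound 4 (0.10 log units; within the scatter). Among the compounds shown here, this is the only step here between compounds differing in one place, and it shows that hydroxy and neopentyloxy read alike at this position on this core. Nothing at hand bears on why the two read alike. As far as these compounds go, it remains open whether an aminoethyl chain or a carboxylic acid on this oxygen would move the number beyond the scatter. From the compounds shown here alone, whether neopentyl reads the same way on the core of compound 1 also stays open.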